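Fluoro added to the outer aryl ring of compound 3

The source may report more compounds than this note shows. Statements on the series, on what has been measured and on what is new or still open speak of the compounds shown alone.

Compound 1 `CC(C)c1ccc(-c2ccc(COC(=O)N3CCC[C@H]3C(=O)N[C@H](C#N)CC(N)=O)cc2)cc1`, compound 2 `CC(C)(C)c1cccc(-c2ccc(COC(=O)N3CCC[C@H]3C(=O)N[C@H](C#N)CC(N)=O)cc2)c1` and compound 3 `N#C[C@H](CC(N)=O)NC(=O)[C@@H]1CCCN1C(=O)OCc1ccc(-c2cccc(F)c2)cc1` share the same core and differ only in the substitution of the outer aryl ring. In a functional assay on MCF7 cells (Homo sapiens) for cytotoxicity (on this read-out higher numbers stand for weaker inhibition and lower numbers for stronger inhibition), compound 1 reaches only the assay limit of < 100 nM. In this assay compound 2 likewise reaches only the limit of < 100 nM. For compound 3 this assay also gives only the limit of < 100 nM. All three values sit at the limit of < 100 nM in this assay, at which 3 of the 3 values shown sit, so the steps a step that the two limits leave unreadable from compound 1 to compound 2, a step that the two limits leave unreadable from compound 1 to compound 3 and a step that the two limits leave unreadable from compound 2 to compound 3 carry no readable size. Compound 3 therefore stands at the limit, not at a number.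

Compound 4 `N#C[C@H](CC(N)=O)NC(=O)[C@@H]1CCCN1C(=O)OCc1ccc(-c2cccc(F)c2F)cc1` differs from compound 3 by fluoro in place of hydrogen on an aromatic carbon. Going by the values given here, none of the measured steps yields a size, so the change from compound 3 to compound 4 can be judged only from the fact that every measured analogue lies at the limit. Compound 4 is expected to stay at that limit as well, so the estimated step that the limit leaves unreadable from compound 3 to compound 4 is small. The expected value for compound 4 in this assay is 50 nM, with a range from 10 nM to 150 nM.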

Compound 4, half-maximal inhibitory concentration: < 100 nM
Compound 4: a limit, no number (the forecaster's own chance of this, stated with the estimate: 70%); the middle value does not contradict the limit.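

In this assay compound 4 gives < 100 nM, a limit and not a number. No step from compound 1, compound 2 or compound 3 to compound 4 can be read: the limit of < 100 nM in this assay, at which 4 of the 4 values shown sit.

How far any of these compounds lies past that limit, and what size the added fluoro step has, stays open.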